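Series notes: aromatic bicycle in place of the non-aromatic ring

A few compounds are considered here, and "the series" means these few. Any claim that something is new, unique, unknown or untested is made for them only; others in the source may bear on it.

Of the compounds shown here, three of the shared core have been measured in a functional assay on PC-3 cells (Homo sapiens) for antiproliferative activity, read by MTT assay, with a stated time of 48 h; a lower number here means a stronger inhibitor, a higher number a weaker inhibitor. Compound 1 `COc1ccc(CN(C(=O)CSc2ccccn2)c2cc(OC)c(OC)c(OC)c2)cc1` gives 7510 nM; compound 3 `COc1ccc(CN(C(=O)CCSc2nc3ccccc3o2)c2cc(OC)c(OC)c(OC)c2)cc1` gives 20200 nM; compound 2 `COc1ccc(CN(C(=O)CSC2=CN=NC2C)c2cc(OC)c(OC)c(OC)c2)cc1` gives 45000 nM, the highest number of the three, with a 6.0-fold higher number from compound 1 to compound 2 (0.78 log units; beyond the scatter) and a 2.2-fold lower number from compound 2 to compound 3 (0.35 log units; beyond the scatter) both beyond the scatter. Compound 4 `COc1ccc(CN(C(=O)CSc2nc3ccccc3[nH]2)c2cc(OC)c(OC)c(OC)c2)cc1` differs from compound 2 in one place: a group of 9 heavy atoms (7 carbon, 2 nitrogen; one five-membered aromatic ring with 2 hetero atoms, one six-membered aromatic ring of carbon only) in place of a group of 6 heavy atoms (4 carbon, 2 nitrogen; one five-membered non-aromatic ring with 2 hetero atoms), on a sulfur. For the measured compounds named here, the steps that bear on this are a 6.0-fold higher number from compound 1 to compound 2 (0.78 log units; beyond the scatter), where the six-membered aromatic ring stood with the lower number, and a 2.2-fold lower number from compound 2 to compound 3 (0.35 log units; beyond the scatter), where a bicyclic aromatic group again stood with the lower number. A lower number for compound 4 is therefore expected, a 5.0-fold lower number from compound 2 to compound 4 (0.70 log units; beyond the scatter). Compound 4 is estimated at 9000 nM, within 3000 nM to 30000 nM.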

Compound 4, half-maximal inhibitory concentration: 14400 nM
Compound 4: the middle estimate sits 1.6-fold (0.20 log units) below what was measured; measured number inside the range.
By their numbers in this assay, from the lowest: compounds 1, 4 and 3 (each within the scatter of the next, the first and the last beyond it); then compound 2.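

In this assay the step to 1H-benzimidazol-2-yl on the sulfur is a 3.1-fold lower number from compound 2 to compound 4 (0.49 log units; beyond the scatter) and so confirms, with a second bicyclic aromatic group, that the non-aromatic five-membered ring is the poorer group here. The other steps, a 1.9-fold higher number from compound 1 to compound 4 (0.28 log units; within the scatter) and a 1.4-fold lower number from compound 3 to compound 4 (0.15 log units; within the scatter), show no separation of 1H-benzimidazol-2-yl from pyridin-2-yl or from ((1,3-benzoxazol-2-yl)sulfanyl)methyl, so the second ring brings no measurable gain over pyridin-2-yl. Nothing available explains these steps.

Still open, going by these compounds, is whether 1-methyl-1H-benzimidazol-2-yl, or an amine or a carboxylic acid on the benzimidazole, would move the number away from this level.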